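This account rests on a few compounds, and the source may have more. Where it says the series, first, only, none or still open, it means among the compounds named here.

Among the three compounds so far measured in a functional assay on MCF7 cells (Homo sapiens) for inhibition (on this read-out higher numbers stand for weaker inhibition and lower numbers for stronger inhibition), compound 3 `CC/C(=C(/c1ccc(/C=C/C(=O)O)cc1)c1cc2ccccc2[nH]1)c1cccc(OC(F)(F)F)c1` gives 282 nM, the highest number of the set; compound 2 `CC/C(=C(/c1ccc(/C=C/C(=O)O)cc1)c1cc2ccccc2[nH]1)c1cccc(C)c1` gives 140 nM, separated only by a 2.0-fold higher number from compound 2 to compound 3 (0.30 log units; within the scatter), and compound 1 `CC/C(=C(/c1ccc(/C=C/C(=O)O)cc1)c1cc2ccccc2[nH]1)c1ccccc1C#N` gives 9 nM. Compound 4 `CC/C(=C(/c1ccc(/C=C/C(=O)O)cc1)c1cc2ccccc2[nH]1)c1ccc(Cl)cc1Cl` differs from compound 3 in one place: 2,4-dichlorophenyl in place of 3-(trifluoromethoxy)phenyl on a double-bonded chain carbon bound to a double-bonded chain carbon and a saturated chain carbon. Among the compounds with values here, the steps that bear on this are the whole-aryl swaps a 16-fold higher number from compound 1 to compound 2 (1.19 log units; beyond the scatter) and a 31-fold higher number from compound 1 to compound 3 (1.50 log units; beyond the scatter), both large, whereas the single-substituent change a 2.0-fold higher number from compound 2 to compound 3 (0.30 log units; within the scatter) stayed within the scatter. The change to compound 4 is again a whole-aryl swap, so a large step is plausible. Compound 1 carrying 2-cyanophenyl gave 9 nM. On that basis the expected step for compound 4 is a 4.7-fold lower number from compound 3 to compound 4 (0.67 log units; beyond the scatter). Compound 4 is estimated at 60 nM, with a range from 12 nM to 300 nM.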

Compound 4, half-maximal inhibitory concentration: 11 nM
Compound 4: the middle estimate sits 5.5-fold (0.74 log units) above what was measured; the whole stated range lies above it.
By their numbers in this assay, from the lowest: compounds 1 and 4 (each within the scatter of the next); then compounds 2 and 3 (each within the scatter of the next).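

At the double-bonded chain carbon, 2,4-dichlorophenyl gives much lower numbers than either aryl group bearing a single substituent at position 3 (a 26-fold lower number from compound 3 to compound 4 (1.41 log units; beyond the scatter); a 13-fold lower number from compound 2 to compound 4 (1.10 log units; beyond the scatter)). Against 2-cyanophenyl it shows no real difference (a 1.2-fold higher number from compound 1 to compound 4 (0.09 log units; within the scatter)), so among these four compounds a nitrile is not required for a number this low. Nothing on hand explains this difference. The compounds shown leave open whether both chlorines are needed, and how a phenyl bearing an amine or a methoxy group would read at this place.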